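A few compounds are considered here, and "the series" means these few. Any claim that something is new, unique, unknown or untested is made for them only; others in the source may bear on it.

Compound 1 `Cc1ccc(Nc2cc(NC(=O)Nc3c(Cl)cccc3Cl)ncn2)cc1C` and compound 2 `CC(C)(C)c1ccc(Nc2cc(NC(=O)Nc3c(Cl)cccc3Cl)ncn2)cc1` share a common core and differ only in the group carried on the outer benzene ring. In a functional assay on NCI-H226 cells (Homo sapiens) for inhibition, read by MTT assay, with a stated time of 48 h, tested at 10 uM (a higher number here means more inhibition at the concentration tested (going by the name of the read-out), a lower number less inhibition), compound 1 gives 41.3%, and in this assay compound 2 gives 40%. Of the two numbers shown, the one for compound 2 stands last, yet its nearest neighbour, compound 1, is separated from it by a gap that falls within the usual scatter, so the two results cannot be told apart. For the measured compounds named here, no single-point step between measured compounds is available.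

Compound 3 `CCc1ccc(Nc2cc(NC(=O)Nc3c(Cl)cccc3Cl)ncn2)cc1` differs from compound 2 by ethyl in place of tert-butyl on an aromatic carbon. Going by the values given here, with no measured step of this sort to lean on, the change is expected to make no difference beyond the scatter, so the step of no change at the digits printed from compound 2 to compound 3 (within the scatter) is estimated to be small. In this assay compound 3 is therefore expected to give about 40%, with a range from 25% to 55%.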

Compound 3, a percentage reported as inhibition, at one concentration (the size of the read-out at that concentration, not a potency): 39.5%
Beside the measured number, compound 3's estimate is 0.5 percentage points above it; the range from low to high includes it.
By their numbers in this assay, from the lowest: compounds 3, 2 and 1 (each within the scatter of the next).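

For the compounds shown here, this is the first measured step at this position. In this assay, ethyl in place of tert-butyl on the aromatic carbon gives a number 0.5 percentage points lower from compound 2 to compound 3 (within the scatter), so these two groups cannot be told apart here. Similarly, 4-ethylphenyl in place of 3,4-dimethylphenyl on a nitrogen on an aromatic ring gives a number 1.8 percentage points lower from compound 1 to compound 3 (within the scatter), which means all three outer rings give matching results, and nothing available explains why.

From the compounds shown here alone, all of these substituents are made of carbon and hydrogen alone, so it remains open how the number would respond to a group containing other atoms, such as an amine or a carboxylic acid. Going by these compounds, it is also open whether a plain phenyl ring, with no group on it, would give the same reading.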